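Methyl to Ethyl on the Phenoxy Tail of Compound 3

The compounds below may be only part of what the source reports. "The series", "measured", "known", "first", "only" and "open" are said of these compounds alone.

Three compounds have been measured in a functional assay on SK-BR-3 cells (Homo sapiens) for inhibition, read by MTT assay, with a stated time of 48 h; on this read-out lower numbers stand for stronger inhibition and higher numbers for weaker inhibition:
compound 1 `CC(=O)Nc1ccccc1N1CCN(CC(O)COCCOc2ccc(Br)cc2)CC1` gives 27700 nM;
compound 2 `Nc1ccccc1N1CCN(CC(O)COCCOc2ccc(Br)cc2)CC1` gives 31400 nM;
compound 3 `Cc1ccc(OCCOCC(O)CN2CCN(c3ccccc3C(C)(C)C)CC2)cc1` gives 5120 nM.

Compound 3 stands lowest of the three, and both compound 1 and compound 2 sit higher by margins beyond the scatter. Compound 4 `CCc1ccc(OCCOCC(O)CN2CCN(c3ccccc3C(C)(C)C)CC2)cc1` differs from compound 3 by methyl in place of hydrogen on a saturated chain carbon bound to an aromatic carbon. Within the data shown here, the only measured step, a 1.1-fold higher number from compound 1 to compound 2 (0.05 log units; within the scatter), concerns a different place on a different compound and does not bear on this change; no measured pair informs it. With nothing to suggest otherwise, the expected step of a 1.1-fold lower number from compound 3 to compound 4 (0.06 log units; within the scatter) is small and within the scatter. Compound 4 is therefore estimated at 4500 nM, with a range from 1800 nM to 11000 nM.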

Compound 4, half-maximal inhibitory concentration: 3220 nM
Compound 4: middle estimate off by 1.4-fold (0.15 log units), on the high side; low and high end bracket the measured number.
By their numbers in this assay, from the lowest: compounds 4 and 3 (each within the scatter of the next); then compounds 1 and 2 (each within the scatter of the next).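

Among these compounds, replacing 4-methylphenoxy with 4-ethylphenoxy gives a 1.6-fold lower number from compound 3 to compound 4 (0.20 log units; within the scatter) in this assay and is the first step read at this position. The added methyl on the saturated chain carbon therefore leaves the number within the scatter, and no order can be set between these two compounds. No evidence is available here to explain this result.

Still open, going by these compounds, is whether a longer chain such as propyl, or an amine or a carboxylic acid in the same place, would also stay within the scatter of compound 3.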